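The source may report more compounds than this note shows. Statements on the series, on what has been measured and on what is new or still open speak of the compounds shown alone.

Working notes on the series. Three compounds have a number in a functional assay on HCC 2998 cells (Homo sapiens) for cytotoxicity, read by sulforhodamine B assay, with a stated time of 48 h, tested at 0.01 uM (on this read-out lower numbers stand for a stronger effect and higher numbers for a weaker effect at the one concentration tested), so far. Compound 1 `COc1ccc(-c2cc(/C=C/C(=O)c3ccc(N)cc3)[nH]n2)cc1` gives 96% and stands second highest of the three; compound 2 `COc1ccc(C(=O)/C=C/c2cc(-c3cc(OC)c(OC)c(OC)c3)n[nH]2)cc1` is nearest, with 101% in this assay, a gap within the scatter, while compound 3 `COc1cc(-c2cc(/C=C/C(=O)c3ccc(F)c(F)c3)[nH]n2)cc(OC)c1OC` is furthest, with 83% in this assay, a gap beyond the scatter. Within the data shown here, the one single-point step recorded is a number 18 percentage points lower from compound 2 to compound 3 (beyond the scatter), a change on the carbonyl side of the shared core.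

Compound 4 `COc1ccc(-c2cc(/C=C/C(=O)c3ccc(N)cc3)[nH]n2)cc1OC` is not yet measured. It differs from compound 1 by methoxy in place of hydrogen on an aromatic carbon, a change on the aryl ring at the other end of the core, ortho to a methoxy group and meta to a large group. Among the measured compounds shown here, no measured step touches this position, and the carbonyl-side step from compound 2 to compound 3 does not bear on it directly. Compound 2, which carries three methoxy groups on that ring, sits within the scatter of compound 1, which gives no sign of a large effect from added methoxy there. A step of a number 1 percentage points higher from compound 1 to compound 4 (within the scatter) is therefore expected, within the scatter. For compound 4 the estimate in this assay is 97%, with a range from 84% to 108%.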

Compound 4, a percentage reported as activity, at one concentration (the size of the read-out at that concentration, not a potency): 102%
Beside the measured number, compound 4's estimate is 5 percentage points below it; the measured number falls inside the stated range.
By their numbers in this assay, from the lowest: compound 3; then compounds 1, 2 and 4 (each within the scatter of the next).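

In this assay, methoxy in place of hydrogen on an aromatic carbon, ortho to a methoxy group and meta to a large group, gives a number 6 percentage points higher from compound 1 to compound 4 (within the scatter). Among these compounds, this is the first step that reads this position on its own, as no earlier step touched it. On this single-concentration read-out, the added methoxy therefore gives no difference that stands clear of the usual scatter, and no measurement at hand speaks to any cause.

From the compounds shown here alone, whether a different group at this place, such as a hydroxyl, a fluorine or an ethoxy, would give a step beyond the scatter stays open. Also open, going by these compounds, is whether the added methoxy would read the same with 3,4-difluorophenyl on the carbonyl carbon, as in compound 3.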